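Replacing the indolyl amine in a sulfonyl pyridopyrimidinone series

This account rests on a few compounds, and the source may have more. Where it says the series, first, only, none or still open, it means among the compounds named here.

Measured so far in a functional assay on DU-145 cells (Homo sapiens) for inhibition, read by trypan blue exclusion, with a stated time of 72 h; a lower number here means a stronger inhibitor, a higher number a weaker inhibitor:
compound 1, `Cn1c(=O)c(S(=O)(=O)Cc2ccc(F)cc2)cc2cnc(Nc3ccc4[nH]ccc4c3)nc21`, 30000 nM
compound 2, `Cn1c(=O)c(S(=O)(=O)c2ccc([N+](=O)[O-])cc2F)cc2cnc(Nc3ccc4[nH]ccc4c3)nc21`, 400 nM
compound 3, `Cc1ccc(S(=O)(=O)c2cc3cnc(Nc4ccc5[nH]ccc5c4)nc3n(C)c2=O)cc1`, 750 nM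

Compound 3 stands second highest of the three numbers. Its nearest neighbour is compound 2, which lies within the scatter of it: a 1.9-fold higher number from compound 2 to compound 3 (0.27 log units; within the scatter). Its furthest is compound 1: a 40-fold lower number from compound 1 to compound 3 (1.60 log units; beyond the scatter), and the related 75-fold lower number from compound 1 to compound 2 (1.88 log units; beyond the scatter) shows the same kind of gap.

Compound 4, `Cc1ccc(S(=O)(=O)c2cc3cnc(Nc4cccc5cccnc45)nc3n(C)c2=O)cc1`, differs from compound 3 at the amine: quinolin-8-yl in place of 1H-indol-5-yl on a nitrogen on an aromatic ring. All three measured steps concern the group on the sulfonyl sulfur, so none of them bears on a change at the amine, and the three measured compounds share the same (1H-indol-5-yl)amino group. There is thus no measured guidance for the size or direction of this step. The change is expected to weaken the inhibitor rather than strengthen it, with wide uncertainty; compound 4 is estimated at 3000 nM, between 500 nM and 20000 nM, meaning an expected step of a 4.0-fold higher number from compound 3 to compound 4 (0.60 log units; beyond the scatter).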

Compound 4, half-maximal inhibitory concentration: 10000 nM
Beside the measured number, compound 4's estimate is 3.3-fold (0.52 log units) below it; the measured number falls inside the stated range.
By their numbers in this assay, from the lowest: compounds 2 and 3 (each within the scatter of the next); then compound 4; then compound 1.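

In this assay, the amine position proves sensitive: with 4-methylphenyl kept on the sulfonyl sulfur, quinolin-8-yl in place of 1H-indol-5-yl gives a 13-fold higher number from compound 3 to compound 4 (1.12 log units; beyond the scatter). The activity in this series therefore depends on the group on this nitrogen as well as on the group on the sulfonyl sulfur. This single swap changes the ring set and trades a hydrogen-bond donor for a hydrogen-bond acceptor, and no measurement here explains the loss or assigns it to any one of these differences.

The compounds shown leave open whether a quinolin-5-yl, naphthalen-1-yl or 1H-indazol-5-yl group on this nitrogen would bring the number back towards that of compound 3. They also leave open whether the step would keep its size with 2-fluoro-4-nitrophenyl on the sulfonyl sulfur.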